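Methoxy to Hydroxy: A Small Step Repeated

The source may hold more compounds than are shown below. What is called first, only, known or untested is meant among the compounds shown, and "the series" means these compounds.

Measured compounds:
compound 1, `COc1ccc2cc(-c3ccc(F)cc3)ccc2c1-c1cccnc1`: 6%
compound 2, `Oc1ccc2cc(-c3ccc(F)cc3)ccc2c1-c1cccnc1`: 0%
compound 3, `COc1ccc2cc(-c3cccc(-c4cccnc4)c3)ccc2c1`: 3%

All three were tested in an assay for inhibition of steroid 17-alpha-hydroxylase/17,20 lyase (Homo sapiens), tested at 0.2 uM; a higher number here means a stronger effect of the compound at the concentration tested, a lower number a weaker effect. At that concentration compound 1 gives 6%, a small effect. Compound 2 differs from compound 1 by one change, (hydrogen in place of methyl on an oxygen on an aromatic ring), and in this assay compound 2 gives 0%. The resulting step, a number 6 percentage points lower from compound 1 to compound 2 (within the scatter), is small and lies within the usual scatter of such measurements, so the two values cannot be told apart with confidence.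

Compound 3 carries a different core; how the core of compound 1 and the core of compound 3 differ is not broken down here. In this assay compound 3 gives 3%, a value that sits within the scatter of both compound 1 and compound 2.

The unmeasured compound 4, `Oc1ccc2cc(-c3cccc(-c4cccnc4)c3)ccc2c1`, is reached from compound 3 by hydrogen in place of methyl on an oxygen on an aromatic ring. Going by the values given here, the surroundings of the changed oxygen are described in the same words for both pairs, so this is the same change as the one from compound 1 to compound 2, made on a different core.

Given that the only measured example of this change stayed within the scatter, the step in this assay is estimated at a number 1 percentage points lower from compound 3 to compound 4 (within the scatter), resting on a number 6 percentage points lower from compound 1 to compound 2 (within the scatter). Compound 4 is therefore expected to give 2%, with a likely range from 0% to 12%.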

Compound 4, a percentage reported as inhibition, at one concentration (the size of the read-out at that concentration, not a potency): 0%
For compound 4 the middle estimate is 2 percentage points above the measured one, within the range that was stated.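

In this assay, the second example of methoxy to hydroxy reads as a number 3 percentage points lower from compound 3 to compound 4 (within the scatter). Set beside the first example, the change looks alike on the two cores: the same change on two cores in this assay, a number 6 percentage points lower (within the scatter) from compound 1 to compound 2 and a number 3 percentage points lower (within the scatter) from compound 3 to compound 4, 3 percentage points apart, within the scatter of two such steps. This agreement is weak support for carrying the change from one core to another, since neither step can be told apart from no change at all, and compound 1 gives 6% and compound 3 gives 3%, so both starting compounds already show only a small effect; the pairs therefore do not show that swapping methyl for hydrogen on this oxygen is harmless on a core with a large effect, nor do they show what the change does at any other concentration.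

The compounds shown carry only methoxy or hydroxy at this oxygen, so it remains open how a longer chain such as ethoxy, or an amine in place of the oxygen, would read in this assay. Also open, as far as these compounds go, is whether the same change would stay this small on a core whose methoxy compound gives a clearly larger effect, where a loss would have room to show.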